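Changing the Amide Partner on a Shared Core

The compounds below may be only part of what the source reports. "The series", "measured", "known", "first", "only" and "open" are said of these compounds alone.

Of the compounds shown here, three sharing one core have been tested in an ADME assay on LLC-MK2 cells (Macaca mulatta) for cytotoxicity, read by spectrophotometry and crystal violet staining, with a stated time of 4 days; on this read-out lower numbers stand for higher toxicity in this test and higher numbers for lower toxicity in this test. Compound 1 `CC(C)n1ncc2c(C(=O)Nc3ccccn3)cc(-c3ccsc3)nc21` gives 25000 nM. Compound 2 `CC(C)n1ncc2c(C(=O)N3CCc4cccnc43)cc(-c3cccs3)nc21` gives 50000 nM. Compound 3 `CC(C)n1ncc2c(C(=O)Nc3ccccc3F)cc(-c3cncs3)nc21` gives 100000 nM. The number for compound 2 sits between those of compound 1 and compound 3, yet each of these gaps lies within the usual scatter of repeated measurements, so the three compounds cannot be told apart on toxicity from these readings alone.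

Compound 4 `CC(C)n1ncc2c(C(=O)Nc3ncccn3)cc(-c3cccs3)nc21` has not yet been measured in this assay. It differs from compound 2 at the carbonyl carbon: a group of 7 heavy atoms (4 carbon, 3 nitrogen; one six-membered aromatic ring with 2 hetero atoms) in place of a group of 9 heavy atoms (7 carbon, 2 nitrogen; one five-membered non-aromatic ring with 1 hetero atom, one six-membered aromatic ring with 1 hetero atom), on a carbonyl carbon. Among the compounds with values here, the group that enters brings one hydrogen-bond donor where the leaving group had none, and the new partner of the carbonyl resembles the one in compound 1, whose value of 25000 nM offers the closest point of comparison.

Within the data shown here, no measured pair among compounds 1, 2 and 3 separates beyond the scatter, so a change of this kind gives no footing for expecting a large move. The step from compound 2 to compound 4 is expected to be small, a 1.7-fold lower number from compound 2 to compound 4 (0.22 log units; within the scatter), likely within the scatter. Compound 4 is estimated to give 30000 nM, with a range from 10000 nM to 100000 nM.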

Compound 4, half-maximal cytotoxic concentration: 75000 nM
Estimate against measurement, compound 4: 2.5-fold (0.40 log units) below; the measured number falls inside the stated range.
By their numbers in this assay, from the lowest: compounds 1, 2, 4 and 3 (each within the scatter of the next, the first and the last beyond it).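

Within the data shown here, this is the first comparison in the set where only one place changes, so the effect of the amide partner can be read without a second change mixed in. In this assay, placing (pyrimidin-2-yl)amino on the carbonyl carbon, where a larger two-ring group stood, gives a 1.5-fold higher number from compound 2 to compound 4 (0.18 log units; within the scatter). In this test, then, the swap adds the amide hydrogen and replaces a non-aromatic ring and a pyridine-type ring with a single aromatic ring bearing two hetero atoms, yet the reading stays inside the normal spread of repeats; nothing measured here explains why the reading responds so little to this change.

This single step describes one pair only, and compounds 1 and 3 each differ from compound 2 and compound 4 in more than one place, so they cannot show whether other amide partners would behave the same way. Going by these compounds, it also remains open whether a partner of a different kind on this carbonyl carbon, such as a simple open-chain alkylamine or a group carrying a carboxylic acid, would stay within the scatter or move the reading beyond it.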